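Methyl Added to the Chlorobenzyl Ether of Compound 1

This account rests on a few compounds, and the source may have more. Where it says the series, first, only, none or still open, it means among the compounds named here.

Compound 1, `Cc1cc(CCC(=O)O)ccc1OCc1ccccc1Cl`: 80%
Compound 2, `Cc1cc(CCC(=O)O)ccc1OCc1ccccc1C(F)(F)F`: 95%

For the measured compounds named here, in a functional assay on cells for agonist activity at Free fatty acid receptor 1 (Homo sapiens), read by FLIPR and calcium flux (on this read-out higher numbers stand for larger maximal responses and lower numbers for smaller maximal responses), compound 1 gives 80%, the lower of the two numbers measured so far. Compound 2 gives 95%, and the step of a number 15 percentage points higher from compound 1 to compound 2 (beyond the scatter) is the only one recorded. Compound 3, `Cc1ccc(Cl)c(COc2ccc(CCC(=O)O)cc2C)c1`, differs from compound 1 by methyl in place of hydrogen on an aromatic carbon. Going by the values given here, the recorded step concerns a different change and bears only loosely on this one; no measured step involves a methyl entering this ring. Compound 3 is therefore expected to reach about 80%, with a range from 65% to 95%. The expected step of no change at the digits printed from compound 1 to compound 3 (within the scatter) lies within the usual scatter.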

Compound 3, largest response reached (reported as percent of maximum), in percent of the reference or control that the assay uses: 243%
Compound 3: the middle estimate sits 163 percentage points below what was measured; the measured number lies above the stated range.
By their numbers in this assay, from the lowest: compound 1; then compound 2; then compound 3.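

In this assay, methyl in place of hydrogen on this aromatic carbon, para to the chloro group and meta to a large group, produces a large change, a number 163 percentage points higher from compound 1 to compound 3 (beyond the scatter), so the maximal response is highly sensitive to this single added carbon. Compounds 1 and 2 carry hydrogen here and could not show this. No available evidence accounts for the size of this step. On these data alone, it remains open whether an ethyl or methoxy group at this position would act like methyl, and whether methyl would have the same effect with trifluoromethyl in place of the chloro group.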